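The source may hold more compounds than are shown below. What is called first, only, known or untested is meant among the compounds shown, and "the series" means these compounds.

Of the compounds shown here, three that share one core have been measured in a functional assay on BXPC-3 cells (Homo sapiens) for inhibition, read by MTT assay, with a stated time of 7 days; a higher number here means a weaker inhibitor, a lower number a stronger inhibitor. Compound 1 `CCN(CC)S(=O)(=O)c1ccc(S(=O)(=O)N2CCC[C@@H](C(=O)N(C)C(C)C)C2)cc1` gives 7700 nM. Compound 2 `CCN(CC)S(=O)(=O)c1ccc(S(=O)(=O)N2CCC[C@@H](C(=O)NC)C2)cc1` gives 13800 nM, and the change is a 1.8-fold higher number from compound 1 to compound 2 (0.25 log units; within the scatter). Compound 3 `CCN(CC)S(=O)(=O)c1ccc(S(=O)(=O)N2CCC[C@@H](c3nc(C)no3)C2)cc1` gives 2900 nM, which makes it the strongest inhibitor of the three: the step is a 2.7-fold lower number from compound 1 to compound 3 (0.42 log units; beyond the scatter) and a 4.8-fold lower number from compound 2 to compound 3 (0.68 log units; beyond the scatter), both beyond the scatter.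

Compound 4 `CCN(CC)S(=O)(=O)c1ccc(S(=O)(=O)N2CCC[C@@H](c3cc(C)no3)C2)cc1` differs from compound 3 in one place: 3-methyl-1,2-oxazol-5-yl in place of 3-methyl-1,2,4-oxadiazol-5-yl on a saturated ring carbon. The measured steps all replace an amide-type group with the five-membered aromatic ring; none of them exchanges one five-membered aromatic ring for another, so they bear only indirectly on this change. What they show is that the two steps into compound 3 were modest in size, and nothing in the numbers says that a second small change at the same position should move the value far. The expected step is therefore one within the scatter, a 1.1-fold higher number from compound 3 to compound 4 (0.04 log units; within the scatter). Compound 4 is estimated at 3200 nM in this assay, with a range from 1200 nM to 8500 nM.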

Compound 4, half-maximal inhibitory concentration: 7700 nM
For compound 4 the middle estimate is 2.4-fold (0.38 log units) below the measured one, within the range that was stated.
By their numbers in this assay, from the lowest: compound 3; then compounds 1, 4 and 2 (each within the scatter of the next).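

Among the compounds shown here, this is the first exchange of one five-membered aromatic ring for another on this saturated ring carbon, and in this assay the swap of 3-methyl-1,2,4-oxadiazol-5-yl for 3-methyl-1,2-oxazol-5-yl gives a 2.7-fold higher number from compound 3 to compound 4 (0.42 log units; beyond the scatter), so the lead of compound 3 does not extend to every five-membered aromatic ring here. Set against the two amides, the new ring gives a 1.8-fold lower number from compound 2 to compound 4 (0.25 log units; within the scatter) and no change at the digits printed from compound 1 to compound 4 (within the scatter), which leaves compound 4 indistinguishable from both. Nothing available explains the gap between the two rings.

Going by these compounds, it remains open whether a 1,3,4-oxadiazole or a tetrazole on this carbon would sit nearer compound 3 or compound 4. On these data alone, the effect of an ethyl or cyclopropyl group in place of the methyl on the ring is also open.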